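The compounds below may be only part of what the source reports. "The series", "measured", "known", "first", "only" and "open" are said of these compounds alone.

Compound 1 `CCCCCC(=O)Nc1cccc(S(=O)(=O)Oc2ccccc2C(C)C)c1`: 11000 nM
Compound 2 `CCC(=O)Nc1ccc(S(=O)(=O)Oc2ccccc2I)cc1`: 7200 nM

In a functional assay on HT-1080 cells (Homo sapiens) for antiproliferative activity, read by sulforhodamine B assay, with a stated time of 48 h (a lower number here means a stronger inhibitor, a higher number a weaker inhibitor), compound 2 gives the lower of the two numbers, but the value of compound 1 lies within the usual scatter of it, so the two cannot be told apart. Compound 3 `CCNC(=O)Nc1ccc(S(=O)(=O)Oc2ccccc2I)cc1` differs from compound 2 in one place: ethylamino in place of ethyl on a carbonyl carbon. Among the compounds with values here, no measured pair shows this change, so the step is expected to stay within the scatter, with no clear direction. For compound 3 the expected value is 7000 nM, within 2500 nM to 20000 nM. This means an expected step of a 1.0-fold lower number from compound 2 to compound 3 (0.01 log units; within the scatter).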

Compound 3, half-maximal inhibitory concentration: 140 nM
Compound 3: middle estimate off by 50-fold (1.70 log units), on the high side; the measured number lies below the stated range.
By their numbers in this assay, from the lowest: compound 3; then compounds 2 and 1 (each within the scatter of the next).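

In this assay, ethylamino in place of ethyl on a carbonyl carbon gives a 51-fold lower number from compound 2 to compound 3 (1.71 log units; beyond the scatter) and so separates compound 3 from two compounds that could not be told apart. This shows that the number responds strongly to a single change at this place, one that turns propanoylamino into (ethylcarbamoyl)amino and adds one nitrogen and one hydrogen-bond donor. Nothing measured here explains the size of this step. The compounds shown leave open whether a longer chain on the new nitrogen, such as butylamino, or a dimethylamino group with no amino hydrogen would keep this gain.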